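A Methoxy Swap on the Weaker Compound

A few compounds are considered here, and "the series" means these few. Any claim that something is new, unique, unknown or untested is made for them only; others in the source may bear on it.

Compound 1 `Cc1ccc(-c2cn(-c3ccc(CN4CCN(C)CC4)c(C(F)(F)F)c3)nn2)cc1Nc1nccc(-c2cccnc2)n1` gives 30 nM
Compound 2 `Cc1ccc(-c2cn(-c3ccc(CN4CCCCC4)cc3)nn2)cc1Nc1nccc(-c2cccnc2)n1` gives 3290 nM

In a functional assay on K562 cells (Homo sapiens) for inhibition, read by MTT assay, with a stated time of 72 h (a higher number here means a weaker inhibitor, a lower number a stronger inhibitor), compound 2 at 3290 nM stands highest of the two measured numbers, and compound 1 at 30 nM lies far lower, beyond the scatter. Compound 3 `COc1ccc(-n2cc(-c3ccc(C)c(Nc4nccc(-c5cccnc5)n4)c3)nn2)cc1` carries methoxy in place of (piperidin-1-yl)methyl on an aromatic carbon para to a large group. Among the compounds with values here, no measured step isolates this change, so only a small step is expected, none beyond the scatter and if anything toward a weaker inhibitor. The expected move is a 1.5-fold higher number from compound 2 to compound 3 (0.18 log units; within the scatter) and remains an estimate. For compound 3 the expected value is 5000 nM with an estimated range from 1500 nM to 20000 nM as the likely span.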

Compound 3, half-maximal inhibitory concentration: > 30000 nM
Compound 3: a limit, no number (the forecaster's own chance of this, stated with the estimate: 20%); middle value at least 6.0-fold (0.77 log units) from the limit.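

Within the data shown here, this is the first change in one place, and it is not small at this position: methoxy in place of (piperidin-1-yl)methyl on an aromatic carbon, para to a large group, gives an at least 9.1-fold higher number from compound 2 to compound 3 (0.95 log units; beyond the scatter) in this assay. Compound 3 gives > 30000 nM, which is a limit of the assay and not a number. The step therefore has no upper end: the limit of > 30000 nM in this assay, at which 1 of the 3 values shown sits.

The compounds shown leave open whether the nitrogen or the ring of the departing group matters more. A (morpholin-4-yl)methyl group or a dimethylaminomethyl group on this carbon could separate the two.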